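A few compounds are considered here, and "the series" means these few. Any claim that something is new, unique, unknown or untested is made for them only; others in the source may bear on it.

Compound 1 (`COC1=C(C)C(=O)C2=C(O[C@@]3(C=C4[C@H](C(C)C)CC[C@@H](C)[C@H]4CC3)C[C@H]2C(C)C)C1(C)C`) reads > 50000 nM in a functional assay on RAW264.7 cells (Mus musculus) for inhibition, read by Griess assay, with stated times of 2 h and 20 h (on this read-out higher numbers stand for weaker inhibition and lower numbers for stronger inhibition), as a limit of the assay and not as a number. Compound 2 (`COC1=C(C)C(=O)C2=C(O[C@]3(CC[C@]45[C@H]([C@H](C(C)C)CC[C@H]4C)[C@@H]35)C[C@H]2C(C)C)C1(C)C`) gives 30500 nM in this assay and compound 3 (`COC1=C(C)C(=O)[C@@]2(CC=C(CCC=C(C)C)C[C@H]2C(C)C)C(=O)C1(C)C`) gives 2070 nM on the same read-out. The position of compound 1 is thus known only as that limit.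

Compound 4 (`COC1=C(C)C(=O)C2=C(O[C@@]3(C=C4[C@H](C(C)C)CC[C@@H](C)[C@H]4CC3)C[C@@H]2C(C)C)C1(C)C`) is the next case: the two compounds have the same atoms and bonds and differ only in configuration as drawn: 1 of 5 stereo elements differ; a stereocentre at a saturated ring carbon is drawn S in compound 1 and R in compound 4 in the comparison with compound 1, a stereocentre at a saturated ring carbon being drawn S in compound 1 and R in compound 4. Within the data shown here, no measured pair isolates such a change. A shift no larger than the scatter is expected, and any movement is expected toward stronger inhibition. The nearest number for this expectation is compound 2 at 30500 nM in the same assay. The expected at least 1.1-fold lower number from compound 1 to compound 4 (0.04 log units; that floor lies within the scatter) is therefore small, and a second reading at the limit remains possible. The estimated value for compound 4 is 45000 nM within an expected range from 20000 nM to 80000 nM on this read-out.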

Compound 4, half-maximal inhibitory concentration: 18800 nM
Compound 4: the middle estimate sits 2.4-fold (0.38 log units) above what was measured, and the stated range ends above it.
By their numbers in this assay, from the lowest: compound 3; then compounds 4 and 2 (each within the scatter of the next). At a limit, above all of these: compound 1.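

In this assay, among these compounds, the drawn configuration at a single saturated ring carbon proves to matter on its own, S to R giving an at least 2.6-fold lower number from compound 1 to compound 4 (0.42 log units; beyond the scatter), the first step that can be read at all. The change in the number can be tied to configuration alone, because no atom or bond changes: the fact that compounds 1 and 4 differ only in the configuration as drawn. The step is only a floor, and its true size stays unfixed: the limit of > 50000 nM in this assay, at which 1 of the 4 values shown sits.

Going by these compounds, compound 2 and compound 3 have no partner that differs from them in one place, so the effect of this configuration on their structures remains unknown. Also open, on these data alone, is whether an amine or a carboxylic acid on the shared core would preserve the difference between the S and R forms.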